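The source may hold more compounds than are shown below. What is called first, only, known or untested is meant among the compounds shown, and "the series" means these compounds.

Compound 1 `N#CNC(=N)Nc1cccnc1` gives 50 mg/kg in a functional assay on the whole organism (blood, strain Wistar-Okamoto) with Rattus norvegicus as the target, with a stated time of 5 days; a lower number here means that less compound is needed, a higher number that more compound is needed for the effect. Compound 3 `CC(/N=C(/NC#N)Nc1cccnc1)C(C)(C)C` gives 1 mg/kg in this assay. Compound 2 `CC(C)CC/N=C(\NC#N)Nc1cccnc1` gives 20 mg/kg in this assay, the second highest of the three numbers: compound 1 stands nearest with a higher number beyond the usual scatter, and compound 3 stands furthest with a lower number, also beyond the scatter. Compound 4 `CCOCC/N=C(\NC#N)Nc1cccnc1` differs from compound 2 in one place: ethoxy in place of isopropyl on a saturated chain carbon, two bonds along the chain from a double-bonded nitrogen. Among the measured compounds shown here, no pair of measured compounds shows a change of this kind, so the data offer no direct step to lean on. The step of a 1.5-fold higher number from compound 2 to compound 4 (0.18 log units; within the scatter) is expected to be small, a modest rise that may not clear the scatter. Compound 4 is therefore estimated at 30 mg/kg, within a range from 8 mg/kg to 100 mg/kg.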

Compound 4, minimum effective dose: > 20 mg/kg
Compound 4: no number, only a limit (the forecaster's own chance of this, stated with the estimate: 10%); the middle value does not contradict the limit.
By their numbers in this assay, from the lowest: compound 3; then compound 2; then compound 1.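

In this assay compound 4 carries only a limit of the assay, > 20 mg/kg. Ethoxy in place of isopropyl gives the first step at this place on the chain, a number no lower from compound 2 to compound 4 (the limit leaves the size open), so the added hydrogen-bond acceptor brought no lower number. The size of that step cannot be read, as the value stands at a limit: the limit of > 20 mg/kg in this assay, at which 1 of the 4 values shown sits.

The compounds shown leave open whether the ether oxygen itself matters, or whether a plain pentyl chain would read the same. They also leave open how an amine or a carboxylic acid at this place would read in this assay.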